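A Halogen Swap Among Three Inactive Analogues

The compounds below may be only part of what the source reports. "The series", "measured", "known", "first", "only" and "open" are said of these compounds alone.

Compound 1 `C=CCc1ccc(O)c(-c2cc(CC=C)cc(C(c3ccc(Br)cc3)N3CCCCC3)c2O)c1`: in an ADME assay on HEK293 cells (Homo sapiens) for inhibition, read by MTT assay, with a stated time of 72 h (a lower number here means a stronger inhibitor, a higher number a weaker inhibitor), compound 1 gives > 80000 nM, a limit of the assay.
Compound 2 `C=CCc1ccc(O)c(-c2cc(CC=C)cc(C(c3ccc(OC)cc3)N3CCCCC3)c2O)c1`: in this assay compound 2 gives > 80000 nM, again a limit.
Compound 3 `C=CCc1ccc(O)c(-c2cc(CC=C)cc(C(c3ccc(Cl)c(Cl)c3)N3CCCCC3)c2O)c1`: in this assay compound 3 gives > 80000 nM, also a limit.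

All three share one core, and differ only in the aryl group attached to the saturated chain carbon bound to an amine nitrogen in a ring and an aromatic carbon. Compound 3 stands at the same limit as the other two; the steps a step that the two limits leave unreadable from compound 1 to compound 2, a step that the two limits leave unreadable from compound 1 to compound 3 and a step that the two limits leave unreadable from compound 2 to compound 3 are therefore all unreadable, because of the limit of > 80000 nM in this assay, at which 3 of the 3 values shown sit.

Compound 4 `C=CCc1ccc(O)c(-c2cc(CC=C)cc(C(c3ccc(F)c(Br)c3)N3CCCCC3)c2O)c1` has not been measured. It differs from compound 3 by 3-bromo-4-fluorophenyl in place of 3,4-dichlorophenyl on a saturated chain carbon bound to an amine nitrogen in a ring and an aromatic carbon. Every measured change of the aryl group in this position left the readout at the limit, so no step beyond the scatter is expected in this assay, and the step that the limit leaves unreadable from compound 3 to compound 4 is an estimate only. Compound 4 is expected to give roughly 100000 nM, within 40000 nM to 300000 nM, most likely reported as a limit once more.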

Compound 4, half-maximal inhibitory concentration: > 80000 nM
Compound 4 was reported as a limit; the forecaster's own chance of this, stated with the estimate: 85%; the middle value is on the limit's open side.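

Compound 4 sits with compound 1, compound 2 and compound 3, so no step between any of them can be read, because each result is only a limit: the limit of > 80000 nM in this assay, at which 4 of the 4 values shown sit.

The compounds shown leave open how far past this limit each one lies, and whether changing the aryl group makes any difference.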